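A few compounds are considered here, and "the series" means these few. Any claim that something is new, unique, unknown or untested is made for them only; others in the source may bear on it.

Measured so far in a functional assay on MCF7 cells (Homo sapiens) for cytotoxicity, read by MTT assay, with stated times of 6 h and 48 h; on this read-out lower numbers stand for stronger inhibition and higher numbers for weaker inhibition:
- compound 1 (`Cn1c(-c2cc(-c3ccccc3)no2)cc(Br)c1Br`): >= 100000 nM as a limit
- compound 2 (`Cn1c(-c2cc(-c3ccccc3O)no2)cc(Br)c1Br`): >= 100000 nM as a limit

Compound 2 stands at >= 100000 nM as a limit and not as a number. Both measured compounds sit at this same limit (the limit of >= 100000 nM in this assay, at which 2 of the 2 values shown sit). Among the measured compounds shown here, the only measured step, hydroxy in place of hydrogen on an aromatic carbon, is a step that the two limits leave unreadable from compound 1 to compound 2 and supplies no size to carry forward.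

Compound 3 (`Oc1ccccc1-c1cc(-c2cc(Br)c(Br)[nH]2)on1`) has hydrogen in place of methyl on an aromatic nitrogen, next to the ring atom that bears a bromo group and next to the ring atom that bears a large group. For the measured compounds named here, no measured step involves this place, so the data do not set the size of the change in this assay. A modest move toward stronger inhibition is expected, though compound 3 may well report only a limit too. The expected change is an at least 3.3-fold lower number from compound 2 to compound 3 (0.52 log units; beyond the scatter) and remains an estimate with wide uncertainty. Compound 3 is estimated at 30000 nM (expected range 5000 nM to 100000 nM).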

Compound 3, half-maximal inhibitory concentration: >= 100000 nM
Compound 3: no number, only a limit; the forecaster's own chance of this, stated with the estimate: 45%; at least 3.3-fold (0.52 log units) between middle value and limit.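

Compound 3 gives >= 100000 nM in this assay as a limit and not a number. No step can be read from compound 2 to compound 3, since all values shown sit at one limit: the limit of >= 100000 nM in this assay, at which 3 of the 3 values shown sit. The compounds shown leave open whether any change to the shared core gives a number in this assay rather than a limit.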